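Swapping the halogenated phenyl ring on a shared core

The source may hold more compounds than are shown below. What is called first, only, known or untested is meant among the compounds shown, and "the series" means these compounds.

Compound 1 `Fc1cc(Cl)ccc1-c1ccc(Cn2nnc3ccccc32)cc1` and compound 2 `Fc1cc(Cl)ccc1-c1ccc(Cn2nnc3ccccc32)cn1` were both characterised in an ADME assay on microsomes from liver (Mus musculus, strain NMRI) for metabolic stability, tested at 2.5 uM; on this read-out lower numbers stand for slow clearance and higher numbers for fast clearance. In this assay compound 1 gives 1.1 mL/min/g, and compound 2 gives 3.4 mL/min/g. For compound 3 `Fc1ccccc1-c1ccc(Cn2nnc3ccccc32)cn1` this assay reports "not determined" (no result reported): its result was not determined, so it stands nowhere on the numbers shown and offers no anchor of its own.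

The step of interest leads from compound 3 to compound 4 `Clc1ccc(-c2ccc(Cn3nnc4ccccc43)cn2)cc1`. The change is 4-chlorophenyl in place of 2-fluorophenyl on an aromatic carbon. Nothing more is known of the two groups than what is counted there: each is a six-membered aromatic ring of carbon only carrying a single halogen, with no hydrogen-bond donors or acceptors and no net charge.

Compound 3 has no number in this assay. The size and direction of the step from it cannot be sized, and no step beyond the usual scatter can be asserted in either direction. What remains is the reading of compound 2, which shares the greater part of its structure with compound 4. In this assay compound 2 gives 3.4 mL/min/g. On that basis compound 4 is expected to give about 2.8 mL/min/g, with a range from 1.2 mL/min/g to 6.5 mL/min/g.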

Compound 4, intrinsic clearance in a liver preparation (reported as CLH), per the amount of preparation that the assay uses: 3.8 mL/min/g
Compound 4: the middle estimate sits 1.4-fold (0.13 log units) below what was measured; measured number inside the range.
By their numbers in this assay, from the lowest: compound 1; then compounds 2 and 4 (each within the scatter of the next).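

With the arrival of compound 4, a 1.1-fold higher number from compound 2 to compound 4 (0.05 log units; within the scatter) in this assay, a step that puts hydrogen in place of fluoro on an aromatic carbon and lies within the usual scatter, so on this shared core the fluoro group makes no difference that this read-out can resolve once the chlorine is present. This is the first reading of that change in the compounds shown, whereas the exchange of 2-fluorophenyl for 4-chlorophenyl itself cannot be read, since compound 3 has no number in this assay and the single-halogen comparison at this position therefore has only one measured end. No measurement is available that would explain why the fluoro group leaves the reading where it is.

From the compounds shown here alone, what the 2-fluorophenyl group alone does to clearance stays open, and so does the question of whether the 4-chlorophenyl group is needed at all at this position on the ring. A group of another kind in place of the chlorine, such as a methoxy group, a nitrile or a morpholine, has no reading among the compounds shown, so how far this position tolerates change remains unknown.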